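Compound 3 to compound 4: pyridin-2-yl in place of methoxy

This account rests on a few compounds, and the source may have more. Where it says the series, first, only, none or still open, it means among the compounds named here.

Values in a functional assay on HCT-116 cells (Homo sapiens) for cytotoxicity, read by fluorescence, with a stated time of 72 h (on this read-out higher numbers stand for weaker inhibition and lower numbers for stronger inhibition), for the series:
- compound 1 `CC(C)c1n[nH]c2c(NCc3ccc(-c4ccccn4)cc3)nc(NCCO)nc12` gives 27 nM
- compound 2 `CC(C)c1n[nH]c2c(NCc3ccc(-c4ccccn4)cc3)nc(NCC(C)(C)O)nc12` gives 85 nM
- compound 3 `COc1ccc(CNc2nc(NCc3ccc(-c4ccccn4)cc3)c3[nH]nc(C(C)C)c3n2)cc1` gives 17400 nM

Compound 3 has the highest number of the three, and so the weakest inhibition in this assay here. Compound 4 `CC(C)c1n[nH]c2c(NCc3ccc(-c4ccccn4)cc3)nc(NCc3ccc(-c4ccccn4)cc3)nc12` differs from it on an aromatic carbon of a six-membered aromatic ring of carbon only, para to a large group, with pyridin-2-yl in place of methoxy on an aromatic carbon here.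

Going by the values given here, no measured step makes this exact change. The nearest evidence lies on the same chain. Two steps are large, a 640-fold higher number from compound 1 to compound 3 (2.81 log units; beyond the scatter) and a 200-fold higher number from compound 2 to compound 3 (2.31 log units; beyond the scatter), each with 4-methoxyphenyl entering. The third, a 3.1-fold higher number from compound 1 to compound 2 (0.50 log units; beyond the scatter), is modest.

Compound 4 keeps an aryl group on that chain, as 4-(pyridin-2-yl)phenyl in place of 4-methoxyphenyl, so a return toward compound 1 at 27 nM is not expected. The step expected in this assay stays within the scatter, with no favoured direction, estimated as a 1.2-fold lower number from compound 3 to compound 4 (0.06 log units; within the scatter) here. Compound 4 is estimated at 15000 nM with an expected range of 3000 nM to 60000 nM overall.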

Compound 4, half-maximal inhibitory concentration: 7330 nM
Beside the measured number, compound 4's estimate is 2.0-fold (0.31 log units) above it; low and high end bracket the measured number.
By their numbers in this assay, from the lowest: compound 1; then compound 2; then compound 4; then compound 3.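

In this assay, pyridin-2-yl in place of methoxy on the aromatic carbon para to a large group gives a modest step beyond the scatter (a 2.4-fold lower number from compound 3 to compound 4 (0.38 log units; beyond the scatter)), so this position responds to a change of group, here toward stronger inhibition. The aryl-bearing chain nevertheless stays far from the two hydroxyl-bearing chains, with large steps on both sides (an 86-fold higher number from compound 2 to compound 4 (1.94 log units; beyond the scatter); a 270-fold higher number from compound 1 to compound 4 (2.43 log units; beyond the scatter)), and the larger para group recovers only a small part of that distance. Nothing measured on these compounds accounts for the step at the aromatic carbon.

As far as these compounds go, it remains open how an amine or a carboxylic acid on that aromatic carbon would read out. From the compounds shown here alone, it is also open whether a longer chain ending in hydroxyl, or a chain ending in an amine, would hold the level of compound 1.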